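The source may hold more compounds than are shown below. What is called first, only, known or untested is meant among the compounds shown, and "the series" means these compounds.

Measured so far in an assay on IM-9 cells for inhibition of Substance-P receptor (Homo sapiens); on this read-out lower numbers stand for stronger inhibition and higher numbers for weaker inhibition:
compound 1, `COc1ccccc1CN[C@H]1C2CCCN(CC2)[C@H]1C(c1ccccc1)c1ccccc1`: 34.3 nM
compound 2, `Clc1ccccc1CN[C@H]1C2CCCN(CC2)[C@H]1C(c1ccccc1)c1ccccc1`: 560 nM

Among the compounds with values here, of these two numbers, compound 2 holds the higher one, and the only other compound, compound 1, sits well away from it: the step of a 16-fold higher number from compound 1 to compound 2 (1.21 log units; beyond the scatter) is the one measured change on this shared core, and it lies beyond the scatter.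

Compound 3, `COc1ccc(CN[C@H]2C3CCCN(CC3)[C@H]2C(c2ccccc2)c2ccccc2)c(OC)c1`, is not yet measured. It differs from compound 2 by 2,4-dimethoxyphenyl in place of 2-chlorophenyl on a saturated chain carbon bound to an amine nitrogen. Within the data shown here, the one measured step that bears on this is a 16-fold higher number from compound 1 to compound 2 (1.21 log units; beyond the scatter), which put a chloro in place of a methoxy on an aromatic carbon and raised the number a great deal. Compound 3 undoes that exchange and also carries a second methoxy, so the expected move in this assay runs the other way and is large. Compound 3 is therefore expected to show a step of a 22-fold lower number from compound 2 to compound 3 (1.35 log units; beyond the scatter). The estimate for compound 3 is 25 nM, with a range from 7 nM to 100 nM. Among the measured compounds shown here, the second methoxy has no precedent among the measured compounds, which widens that range.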

Compound 3, half-maximal inhibitory concentration: 86.3 nM
Compound 3: middle estimate off by 3.5-fold (0.54 log units), on the low side; the measured number falls inside the stated range.
By their numbers in this assay, from the lowest: compound 1; then compound 3; then compound 2.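

In this assay, replacing 2-chlorobenzyl with 2,4-dimethoxybenzyl gives a 6.5-fold lower number from compound 2 to compound 3 (0.81 log units; beyond the scatter), so methoxy groups on this ring again go with a lower number than the chloro compound, though this step is smaller than the earlier chloro-for-methoxy step. The new information comes from the comparison with compound 1: putting a second methoxy in place of hydrogen on an aromatic carbon gives a 2.5-fold higher number from compound 1 to compound 3 (0.40 log units; beyond the scatter), so adding methoxy here does not lower the number further, and compound 1 keeps the lowest number of the three. Nothing measured here explains either step.

The compounds shown leave open whether a hydroxyl, an ethoxy group or an amine in place of either methoxy would lower the number, raise it or leave it within the usual scatter. The rest of the shared core is identical in all three compounds, so they also cannot show how changes there would affect these numbers or whether the methoxy steps would hold on a different core.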